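Ring size at the amide-bound amine: compound 3 to compound 4

The source may report more compounds than this note shows. Statements on the series, on what has been measured and on what is new or still open speak of the compounds shown alone.

Working notes on the series of 2-anilinoquinoline-type compounds sharing one core, varied only at the basic amine attached to the saturated chain carbon bound to the carbonyl carbon. Compound 1 `COc1ccc(-c2cc3cc(OC)ccc3nc2Nc2ccc(NC(=O)CN(C)C)cc2)cc1`, carrying dimethylamino there, gives in a functional assay on HUVEC cells (Homo sapiens) for antiproliferative activity, read by MTT assay, with a stated time of 48 h (on this read-out higher numbers stand for weaker inhibition and lower numbers for stronger inhibition), a value of 22200 nM. Compound 2 `CCN(CC)CC(=O)Nc1ccc(Nc2nc3ccc(OC)cc3cc2-c2ccc(OC)cc2)cc1`, with diethylamino, gives 45600 nM. Compound 3 `COc1ccc(-c2cc3cc(OC)ccc3nc2Nc2ccc(NC(=O)CN3CCCC3)cc2)cc1`, with pyrrolidin-1-yl, gives 13100 nM, the lowest of the three numbers; its gap to compound 1 is within the scatter, its gap to compound 2 is beyond it.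

The measured steps at this position: a 2.1-fold higher number from compound 1 to compound 2 (0.31 log units; beyond the scatter); a 1.7-fold lower number from compound 1 to compound 3 (0.23 log units; within the scatter); a 3.5-fold lower number from compound 2 to compound 3 (0.54 log units; beyond the scatter).

Compound 4 `COc1ccc(-c2cc3cc(OC)ccc3nc2Nc2ccc(NC(=O)CN3CCCCC3)cc2)cc1` differs from compound 3 in one place: piperidin-1-yl in place of pyrrolidin-1-yl on a saturated chain carbon bound to a carbonyl carbon. Among the compounds with values here, no measured step enlarges a ring here. The nearest comparisons are the growth from dimethylamino to diethylamino, which raised the number modestly, and the move to the five-membered ring, which lowered it. For compound 4 a step no larger than the scatter is expected, if anything toward a slightly higher number, giving a 1.4-fold higher number from compound 3 to compound 4 (0.14 log units; within the scatter). Compound 4 is therefore estimated at 18000 nM, within 8000 nM to 40000 nM.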

Compound 4, half-maximal inhibitory concentration: > 50000 nM
Compound 4: a limit, no number; the forecaster's own chance of this, stated with the estimate: 5%; middle value at least 2.7-fold (0.44 log units) away from the limit.
By their numbers in this assay, from the lowest: compounds 3 and 1 (each within the scatter of the next); then compound 2. At a limit, above all of these: compound 4.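

In this assay compound 4 gives only a limit of the assay, not a number: the limit of > 50000 nM in this assay, at which 1 of the 4 values shown sits.

Even so, enlarging the five-membered ring to the six-membered ring on a saturated chain carbon bound to a carbonyl carbon is not a neutral change, with an at least 3.8-fold higher number from compound 3 to compound 4 (0.58 log units; beyond the scatter), whereas the earlier compounds showed the five-membered ring only as within the scatter of dimethylamino. Against the open chain the floors differ: the data give an at least 2.2-fold higher number from compound 1 to compound 4 (0.35 log units; beyond the scatter) but only an at least 1.0-fold higher number from compound 2 to compound 4 (0.04 log units; that floor lies within the scatter), a floor within the scatter, so compound 4 has no fixed order against compound 2.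

How far compound 4 lies past its limit cannot be read. Open too, going by these compounds, is whether morpholin-4-yl or 4-methylpiperazin-1-yl, with a second ring hetero atom, would follow piperidin-1-yl or pyrrolidin-1-yl at this place.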